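The source may report more compounds than this note shows. Statements on the series, on what has been measured and on what is new or still open speak of the compounds shown alone.

Measured compounds:
- compound 1 `O=[N+]([O-])c1nccn1CS(=O)(=O)NCCN1CCCC1`: 11000 nM
- compound 2 `O=C(O)CNS(=O)(=O)Cn1ccnc1[N+](=O)[O-]`: 900000 nM
- compound 3 `O=C(O)CCNS(=O)(=O)Cn1ccnc1[N+](=O)[O-]`: 4400000 nM

In a functional assay on HCT-116 cells (Homo sapiens) for cytotoxicity, read by sulforhodamine B assay, with stated times of 4 h and 5 days (a higher number here means a weaker inhibitor, a lower number a stronger inhibitor), compound 3 gives the highest number of the three: it lies a 4.9-fold higher number from compound 2 to compound 3 (0.69 log units; beyond the scatter) and a 400-fold higher number from compound 1 to compound 3 (2.60 log units; beyond the scatter), so it is the weakest of this small set, with every step to the others beyond the scatter.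

Compound 4 `O=[N+]([O-])c1nccn1CS(=O)(=O)NN1CCOCC1` differs from compound 3 in one place: morpholin-4-yl in place of 2-carboxyethyl on a sulfonamide nitrogen. The most relevant measured step runs the other way, from a cyclic amine to a carboxylic acid: a 400-fold higher number from compound 1 to compound 3 (2.60 log units; beyond the scatter), and the related step of an 82-fold higher number from compound 1 to compound 2 (1.91 log units; beyond the scatter) points the same way. Both show that exchanging an acid chain for a ring-bearing amine group on this side of the sulfonamide moves the number a long way down. Compound 4 does not return to the exact arrangement of compound 1, so only part of that movement is expected. A large drop in number, a 73-fold lower number from compound 3 to compound 4 (1.87 log units; beyond the scatter), is therefore expected, and compound 4 is estimated at 60000 nM, within a range of 8000 nM to 400000 nM.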

Compound 4, half-maximal inhibitory concentration: 30000 nM
The estimate for compound 4 lay 2.0-fold (0.30 log units) above the measured number, within the range that was stated.
By their numbers in this assay, from the lowest: compound 1; then compound 4; then compound 2; then compound 3.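

In this assay, morpholin-4-yl in place of 2-carboxyethyl on the sulfonamide nitrogen gives a 150-fold lower number from compound 3 to compound 4 (2.17 log units; beyond the scatter), and morpholin-4-yl in place of carboxymethyl gives a 30-fold lower number from compound 2 to compound 4 (1.48 log units; beyond the scatter). Before this result, the only compound far below the two carboxylic acids carried pyrrolidin-1-yl at the end of a chain, whereas here a six-membered ring with 2 hetero atoms, attached directly to the sulfonamide nitrogen, also lies far below them, so the large fall is not tied to that single group. No measurement available here explains this fall.

From the compounds shown here alone, it remains open whether the fall comes from gaining the ring or simply from losing the carboxylic acid. A plain ethyl group or a piperidin-1-yl ring on the same nitrogen would help separate these two readings.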